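Swapping an isobutyl for a benzyl on the amide

The source may hold more compounds than are shown below. What is called first, only, known or untested is meant among the compounds shown, and "the series" means these compounds.

Measured so far: compound 1 `C=CC1=C(C(=O)NCc2ccccc2F)C(c2ccc(F)cc2)OC1` with > 100000 nM, and compound 2 `C=CC1=C(C(=O)NCC(C)C)C(c2ccc(Cl)c(Cl)c2)OC1` with 60100 nM.

In a functional assay on HeLa cells (Homo sapiens) for cytotoxicity, read by MTT assay, with a stated time of 24 h (on this read-out lower numbers stand for stronger inhibition and higher numbers for weaker inhibition), compound 1 gives > 100000 nM, which is a limit of the assay rather than a number; this is the limit of > 100000 nM in this assay, at which 1 of the 2 values shown sits. Compound 2 gives 60100 nM in this assay, the only number shown, so it stands alone. Compound 3 `C=CC1=C(C(=O)NCc2ccccc2)C(c2ccc(Cl)c(Cl)c2)OC1` carries phenyl in place of isopropyl on a saturated chain carbon bound to an amide-type nitrogen. No measured step of this kind is shown, so only a small change is expected, within the scatter or slightly weaker: the step of a 1.2-fold higher number from compound 2 to compound 3 (0.07 log units; within the scatter) is the estimate. Compound 3 is expected to give 70000 nM, ranging from 30000 nM to 150000 nM.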

Compound 3, half-maximal inhibitory concentration: > 100000 nM
Compound 3 was reported as a limit; the forecaster's own chance of this, stated with the estimate: 35%; at least 1.4-fold (0.15 log units) between middle value and limit.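

In this assay compound 3 gives > 100000 nM as a limit of the assay and not a number. Phenyl in place of isopropyl on this saturated chain carbon therefore brings no stronger inhibition, with an at least 1.6-fold higher number from compound 2 to compound 3 (0.22 log units; that floor lies within the scatter) as the step, and its true size cannot be read. Only compound 2 gives a number here, and the others stop at the top of the range: the limit of > 100000 nM in this assay, at which 2 of the 3 values shown sit.

Going by these compounds, how far compound 3 lies past its limit stays open. So does how an amine, a carboxylic acid or a longer chain in place of the isopropyl would read.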